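This account rests on a few compounds, and the source may have more. Where it says the series, first, only, none or still open, it means among the compounds named here.

Measured compounds:
- Compound 1, `O=C(NO)c1ccc(-c2cn([C@H]3C[C@H](C(=O)O)N(CCCc4ccccc4)C3)nn2)cc1`: in an assay on Sf9 cells for inhibition of histone deacetylase 11 (Homo sapiens), read by fluorescence, tested at 0.5 uM (on this read-out higher numbers stand for more inhibition at the one concentration tested (going by the name of the read-out) and lower numbers for less inhibition), compound 1 gives < 10%, which is a limit of the assay and not a number.
- Compound 2, `O=C(NO)c1cccc(-c2cn([C@@H]3C[C@H](C(=O)O)N(CCCc4ccccc4)C3)nn2)c1`: in this assay compound 2 gives < 10%, likewise a limit rather than a number.

Compound 2 therefore stands at the floor of what this assay reports, and both measured compounds sit at that same limit, as the limit of < 10% in this assay, at which 2 of the 2 values shown sit, records. Nothing here separates the two.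

Compound 3, `O=C(NO)c1cccc(-c2cn([C@H]3C[C@H](C(=O)O)N(CCCc4ccccc4)C3)nn2)c1`, is not yet measured. Its difference from compound 2 is small: the two compounds have the same atoms and bonds and differ only in configuration as drawn: 1 of 2 stereo elements differ; a stereocentre at a saturated ring carbon is drawn R in compound 2 and S in compound 3. Among the compounds with values here, no pair of measured compounds shows how such a change of configuration moves the read-out, so the size of the step is unknown from these data. The expected change in this assay is a step that the limit leaves unreadable from compound 2 to compound 3, that is, nothing beyond the usual scatter. Compound 3 is therefore estimated at 5% in this assay, within a range from 0% to 15%, most likely reported again only as a limit.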

Compound 3, a percentage reported as inhibition, at one concentration (the size of the read-out at that concentration, not a potency): < 10%
Compound 3 gave a limit, no number (the forecaster's own chance of this, stated with the estimate: 80%); the middle value lies beyond the limit too.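

No step between compound 1, compound 2 and compound 3 can be read in this assay, since each result is a limit and not a number: the limit of < 10% in this assay, at which 3 of the 3 values shown sit.

The compounds shown leave open whether the change of configuration, or 3-(hydroxycarbamoyl)phenyl in place of 4-(hydroxycarbamoyl)phenyl, moves the inhibition at all.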